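Urea series: heteroaryl swaps and liver clearance

The source may hold more compounds than are shown below. What is called first, only, known or untested is meant among the compounds shown, and "the series" means these compounds.

Measured so far:
compound 1, `O=C(Nc1ccc(F)c(C(F)(F)F)c1)Nc1cnccn1`: 160 uL/min
compound 2, `O=C(Nc1ccc(F)c(C(F)(F)F)c1)Nc1ccccn1`: 705 uL/min
compound 3, `Cc1cc(NC(=O)Nc2ccc(F)c(C(F)(F)F)c2)on1`: 108 uL/min

All numbers come from an ADME assay on microsomes from liver (Mus musculus) for metabolic stability, using NADPH, with a stated time of 60 min; on this read-out higher numbers stand for fast clearance and lower numbers for slow clearance. Compound 3 sits at the low end of the three; its gap to compound 1 is within the scatter, whereas a 6.5-fold lower number from compound 2 to compound 3 (0.81 log units; beyond the scatter) lies beyond it. Compound 4 `O=C(Nc1cccnc1)Nc1ccc(F)c(C(F)(F)F)c1` is the next step: pyridin-3-yl in place of 3-methyl-1,2-oxazol-5-yl on an amide-type nitrogen. Two earlier steps bear on this change: a 1.5-fold lower number from compound 1 to compound 3 (0.17 log units; within the scatter) and a 4.4-fold higher number from compound 1 to compound 2 (0.64 log units; beyond the scatter). Among the measured compounds shown here, the six-membered ring with one nitrogen was carried by compound 2, the highest number so far, so a rise beyond the scatter is expected, though smaller than that seen for compound 2. Compound 4 is therefore estimated at 330 uL/min, range 120 uL/min to 900 uL/min. The expected step is a 3.1-fold higher number from compound 3 to compound 4 (0.49 log units; beyond the scatter).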

Compound 4, intrinsic clearance in a liver preparation (reported as CLH), per the amount of preparation that the assay uses: 154 uL/min
Compound 4: the middle estimate sits 2.1-fold (0.33 log units) above what was measured; measured number inside the range.
By their numbers in this assay, from the lowest: compounds 3, 4 and 1 (each within the scatter of the next); then compound 2.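

The high number of compound 2 does not come with every six-membered ring carrying one ring nitrogen: a 4.6-fold lower number from compound 2 to compound 4 (0.66 log units; beyond the scatter) separates the two pyridine attachments in this assay. Neither a 1.4-fold higher number from compound 3 to compound 4 (0.15 log units; within the scatter) nor a 1.0-fold lower number from compound 1 to compound 4 (0.02 log units; within the scatter) resolves pyridin-3-yl from 3-methyl-1,2-oxazol-5-yl or pyrazin-2-yl, so among the compounds shown only pyridin-2-yl stands apart. The data shown offer no explanation for the gap between the pyridin-2-yl and pyridin-3-yl compounds.

Still open, from the compounds shown here alone, is whether pyridin-4-yl would fall with compound 2 or with compound 4. A methyl or an amine on the pyridin-2-yl ring also remains an open case.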